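Fluoro and methoxy on the phenyl of compound 1

The source may report more compounds than this note shows. Statements on the series, on what has been measured and on what is new or still open speak of the compounds shown alone.

In a functional assay on HL-60 cells (Homo sapiens) for activation, read by flow cytometry, with a stated time of 4 days (on this read-out lower numbers stand for an effect already at smaller amounts and higher numbers for an effect only at larger amounts of compound), compound 1 (`COc1ccc(-n2cnc3cnc(-c4ccccc4)cc32)cc1OC`) gives 1600 nM. That lies within the scatter of compound 3 (`COc1ccc(-n2cnc3cnc(-c4cc(F)ccc4C)cc32)cc1OC`), which gives 2500 nM, and far from compound 2 (`COc1ccc(-n2cnc3cnc(-c4ccccc4C)cc32)cc1OC`), which gives 69 nM.

The step to compound 4 (`COc1ccc(-n2cnc3cnc(-c4cc(F)ccc4OC)cc32)cc1OC`) puts 5-fluoro-2-methoxyphenyl in place of phenyl on an aromatic carbon. Going by the values given here, three measured steps bear on it. Methyl in place of hydrogen gave a large change, a 23-fold lower number from compound 1 to compound 2 (1.37 log units; beyond the scatter). Fluoro in place of hydrogen then gave an equally large change the opposite way, a 36-fold higher number from compound 2 to compound 3 (1.56 log units; beyond the scatter). The two together leave only a 1.6-fold higher number from compound 1 to compound 3 (0.19 log units; within the scatter). Among the compounds with values here, compound 4 carries methoxy rather than methyl, and no measured compound shows that group, so the comparison with compound 3 is uncertain. Compound 3 is still the closest guide, so no change beyond the scatter is expected. The expected step is a 1.1-fold lower number from compound 1 to compound 4 (0.03 log units; within the scatter). For compound 4 the estimated value is 1500 nM, with an expected range from 250 nM to 6000 nM.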

Compound 4, half-maximal effective concentration: 1300 nM
Estimate against measurement, compound 4: 1.2-fold (0.06 log units) above; measured number inside the range.
By their numbers in this assay, from the lowest: compound 2; then compounds 4, 1 and 3 (each within the scatter of the next).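

In this assay, methoxy in place of methyl gives a 1.9-fold lower number from compound 3 to compound 4 (0.28 log units; within the scatter) on the fluorine-bearing ring, so the two groups are not told apart there. With 5-fluoro-2-methoxyphenyl in place of phenyl there is a 1.2-fold lower number from compound 1 to compound 4 (0.09 log units; within the scatter) and, against the 2-methylphenyl of compound 2, a 19-fold higher number from compound 2 to compound 4 (1.28 log units; beyond the scatter) at this position, so a second fluoro-bearing compound now stays within the scatter of compound 1, and among the four only compound 2 stands apart. Nothing at hand accounts for these steps.

As far as these compounds go, it remains open whether a plain 2-methoxyphenyl, without the fluoro, would lie close to compound 2 or to compound 4. Also open, from the compounds shown here alone, is whether chloro or an amine in the place of the fluoro would bring the same large rise as fluoro did in compound 3.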